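Ethoxy for hydrogen on a carbonyl carbon

The compounds below may be only part of what the source reports. "The series", "measured", "known", "first", "only" and "open" are said of these compounds alone.

Going by the values given here, compound 2 `Nc1ncnc2c1ncn2/C=C/C=O` is one of three compounds measured in a functional assay on HeLa cells (Homo sapiens) for inhibition; a higher number here means a weaker inhibitor, a lower number a stronger inhibitor. In this assay compound 2 gives only a limit, > 100000 nM. Compound 1 `Nc1ccn(/C=C/C=O)c(=O)n1` likewise gives only a limit, > 100000 nM. Compound 3 `CC(=O)/C=C/n1cc(C)c(=O)[nH]c1=O` also gives only a limit, > 100000 nM. Among the compounds with values here, all three sit at the limit of > 100000 nM in this assay, at which 3 of the 3 values shown sit, so compound 2 stands where every measured compound stands, with no number and no measured step to compare against. Compound 4 `CCOC(=O)/C=C/n1cnc2c(N)ncnc21` differs from compound 2 in one place: ethoxy in place of hydrogen on a carbonyl carbon. Within the data shown here, no measured step shows what this change does to inhibition. The expected step of a number no higher from compound 2 to compound 4 (the limit leaves the size open) is none beyond the scatter. Compound 4 is therefore estimated at 100000 nM, within 30000 nM to 300000 nM, most likely reported again only as a limit.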

Compound 4, half-maximal inhibitory concentration: 100000 nM
For compound 4 middle estimate and measured number coincide at the digits printed, and the stated range covers the measured number.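

In this assay, going by these compounds alone, compound 4 gives 100000 nM, the only value shown that is a number rather than a limit, and ethoxy in place of hydrogen on this carbonyl carbon gives a number no higher from compound 2 to compound 4 (the limit leaves the size open). Compound 2 gives only a limit, > 100000 nM. The size of the change from formyl to ethoxycarbonyl cannot be read, and most of the series stays at that limit: the limit of > 100000 nM in this assay, at which 3 of the 4 values shown sit.

As far as these compounds go, it remains open whether a carboxylic acid, an amide or a longer chain on this carbonyl carbon would give a lower number. From the compounds shown here alone, it is also open what ethoxy would do on the core of compound 1.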